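A few compounds are considered here, and "the series" means these few. Any claim that something is new, unique, unknown or untested is made for them only; others in the source may bear on it.

Measured so far in an assay on membranes from CHO cells for displacement of a labelled ligand from adenosine receptor A1 (Homo sapiens), read by scintillation counting, with a stated time of 60 min, tested at 1 uM; a higher number here means more inhibition at the concentration tested (going by the name of the read-out), a lower number less inhibition:
compound 1 `CCCC(=O)C1=C(C)NC(=O)NC1c1cccs1`, 2%
compound 2 `CC1=C(C(=O)CC(C)C)C(c2cccs2)NC(=O)N1`, 19%
compound 3 `CCCC(=O)C1=C(C)NC(=O)NC1c1ccsc1`, 6%

Compound 4 `CC1=C(C(=O)CC(C)C)C(c2ccsc2)NC(=O)N1` has not yet been measured in this assay. It differs from compound 3 by methyl in place of hydrogen on a saturated chain carbon bound to two saturated chain carbons. Compound 2 differs from compound 1 by methyl in place of hydrogen on a saturated chain carbon bound to two saturated chain carbons, the same change at the same place, and this step gave a number 17 percentage points higher from compound 1 to compound 2 (beyond the scatter). The two cores differ by thiophen-3-yl in place of thiophen-2-yl on a saturated ring carbon, a change which gave a number 4 percentage points higher from compound 1 to compound 3 (within the scatter), so compound 1 and compound 3 sit within the scatter of each other. Going by the values given here, the step of a number 16 percentage points higher from compound 3 to compound 4 (beyond the scatter) is estimated because a number 17 percentage points higher from compound 1 to compound 2 (beyond the scatter) is the only measured instance of this change and the two cores show no separated difference. Compound 4 is therefore expected to give 22% in this assay, with the range 8% to 38%.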

Compound 4, a percentage reported as inhibition, at one concentration (the size of the read-out at that concentration, not a potency): 37%
For compound 4 the middle estimate is 15 percentage points below the measured one; the measured number falls inside the stated range.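

In this assay, methyl in place of hydrogen on a saturated chain carbon bound to two saturated chain carbons gave a number 31 percentage points higher from compound 3 to compound 4 (beyond the scatter), and its size does not separate from that of the same change on the other core: the same change on two cores in this assay, a number 17 percentage points higher (beyond the scatter) from compound 1 to compound 2 and a number 31 percentage points higher (beyond the scatter) from compound 3 to compound 4, 14 percentage points apart, within the scatter of two such steps. Thiophen-3-yl in place of thiophen-2-yl gave a number 18 percentage points higher from compound 2 to compound 4 (beyond the scatter), which likewise does not separate from the earlier step: the same change on two cores in this assay, a number 4 percentage points higher (within the scatter) from compound 1 to compound 3 and a number 18 percentage points higher (beyond the scatter) from compound 2 to compound 4, 14 percentage points apart, within the scatter of two such steps. The methyl step thus has the same direction on both cores, but two pairs do not show whether its size depends on the core, and single-concentration inhibition is not a potency.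

From the compounds shown here alone, whether a longer chain in place of isobutylcarbonyl would continue this direction remains open. So does the effect of an amine at that place.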